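The compounds below may be only part of what the source reports. "The series", "measured", "known", "first", "only" and "open" are said of these compounds alone.

Compound 1 `Cc1cc(O)c(C(C)C)cc1-c1cc(-c2ccccc2)c(C#N)c(=O)[nH]1` gives 34% in a functional assay for inhibition, tested at 60 ug/mL; on this read-out lower numbers stand for a weaker effect and higher numbers for a stronger effect at the one concentration tested. Going by the values given here, compound 2 `COc1cccc(-c2cc(-c3cc(C(C)C)c(O)cc3C)[nH]c(=O)c2C#N)c1` gives 38% in this assay, and compound 3 `COc1ccc(-c2cc(-c3cc(C(C)C)c(O)cc3C)[nH]c(=O)c2C#N)c(OC)c1` gives 48.5% in this assay, the highest of the three numbers so far. The step of a number 4 percentage points higher from compound 1 to compound 2 (within the scatter) goes with the change (methoxy in place of hydrogen on an aromatic carbon). The steps of a number 14.5 percentage points higher from compound 1 to compound 3 (beyond the scatter) and a number 10.5 percentage points higher from compound 2 to compound 3 (beyond the scatter) are both modest. Compound 4 `COc1cc(OC)c(-c2cc(-c3cc(C(C)C)c(O)cc3C)[nH]c(=O)c2C#N)c(OC)c1` has not yet been measured in this assay. It differs from compound 3 by methoxy in place of hydrogen on an aromatic carbon. The two cores that carry this change differ by 2,4-dimethoxyphenyl in place of phenyl on an aromatic carbon. In compound 2 the entering group sits meta to a large group; in compound 4 it sits ortho to a large group and meta to two methoxy groups, so this is the same kind of change, not the same change. The expected step of a number 4.5 percentage points higher from compound 3 to compound 4 (within the scatter) is set beside a number 4 percentage points higher from compound 1 to compound 2 (within the scatter), and it rests on compound 2 with 38% read against compound 1 with 34%. Compound 4 is estimated at 53%, with an expected range from 38% to 67%.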

Compound 4, a percentage reported as inhibition, at one concentration (the size of the read-out at that concentration, not a potency): 66%
Compound 4: middle estimate off by 13 percentage points, on the low side; measured number inside the range.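

In this assay, methoxy in place of hydrogen on an aromatic carbon goes with a number 17.5 percentage points higher from compound 3 to compound 4 (beyond the scatter), and the two examples of this change cannot be told apart: the same change on two cores in this assay, a number 4 percentage points higher (within the scatter) from compound 1 to compound 2 and a number 17.5 percentage points higher (beyond the scatter) from compound 3 to compound 4, 13.5 percentage points apart, within the scatter of two such steps. Carrying the change from the core of compound 1 to the core of compound 3 therefore meets no contradiction, although only the later step lies beyond the scatter on its own. Two pairs do not show that the step depends on the core or fix its size, and the entering methoxy does not sit in the same place in the two pairs, ortho to a large group and meta to two methoxy groups in compound 4.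

All substituents on this aromatic ring in the compounds shown are methoxy groups, so it remains open how an amine, a carboxylic acid or a longer chain such as butoxy would read at the same place. Each number also comes from one concentration, so it shows only a stronger or weaker effect at that concentration.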